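A few compounds are considered here, and "the series" means these few. Any claim that something is new, unique, unknown or untested is made for them only; others in the source may bear on it.

Among the measured compounds shown here, compound 2 `O=C(Nc1cnc(NCc2c(F)ccc3c2CCO3)n2cnnc12)c1ccccc1` is one of three compounds measured in a physicochemical assay for solubility, read by LC-MS, in phosphate buffer, with a stated time of 24 h, at pH 7.4; on this read-out higher numbers stand for higher solubility and lower numbers for lower solubility. Compound 2 gives 2000 nM, level at the digits shown with compound 3 `Cn1nccc1-c1cnc(NCc2c(F)ccc3c2CCO3)c2cn[nH]c(=O)c12`, which gives 2000 nM; together they are the lowest of the three numbers, and the furthest of the three from compound 2 is compound 1 `CN(C)C(=O)c1cc(-c2cnc(NCc3c(F)ccc4c3CCO4)c3cn[nH]c(=O)c23)n(C)n1`, which gives 3000 nM, a difference that lies within the scatter. For the measured compounds named here, the one step available between measured compounds, a 1.5-fold lower number from compound 1 to compound 3 (0.18 log units; within the scatter), removes dimethylcarbamoyl from an aromatic carbon and stays within the scatter.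

Compound 4 `Fc1ccc2c(c1CNc1ncc(Nc3ccccc3)c3nncn13)CCO2` is not yet measured. Its change from compound 2 is phenyl in place of benzoyl on a nitrogen on an aromatic ring: the leaving benzoyl carries one hydrogen-bond acceptor and one double bond outside aromatic rings, and the entering phenyl carries neither. Going by the values given here, no measured step makes exactly this change; the nearest is the loss of dimethylcarbamoyl from compound 1 to compound 3, which stayed within the scatter. On that basis the step from compound 2 to compound 4 in this assay is expected to be small, a 1.3-fold lower number from compound 2 to compound 4 (0.12 log units; within the scatter), with no direction beyond the scatter claimed. Compound 4 is therefore estimated at 1500 nM, in the range 500 nM to 5000 nM.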

Compound 4, solubility: 3000 nM
Beside the measured number, compound 4's estimate is 2.0-fold (0.30 log units) below it; low and high end bracket the measured number.
By their numbers in this assay, from the lowest: compounds 2, 3, 1 and 4 (each within the scatter of the next).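

In this assay the change from benzamido to anilino gives a 1.5-fold higher number from compound 2 to compound 4 (0.18 log units; within the scatter) and so stays within the scatter. Among the compounds shown here, this is the first step read on a nitrogen on an aromatic ring, and it shows that at this place benzoyl can give way to phenyl, which carries no hydrogen-bond acceptor, without a step beyond the scatter; the only earlier step lay on an aromatic carbon of a different core. Nothing available accounts for this result.

The compounds shown leave open whether a longer chain or a carboxylic acid in place of phenyl at this nitrogen would give a step beyond the scatter in this assay. They also leave open whether the same change would read alike on the core of compound 3.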